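Trifluoromethoxy for Trifluoromethyl on the Aryl Ether

This account rests on a few compounds, and the source may have more. Where it says the series, first, only, none or still open, it means among the compounds named here.

In a functional assay on CRL2813 cells (Homo sapiens) for cytotoxicity, read by sulforhodamine B assay, with a stated time of 5 days (on this read-out higher numbers stand for weaker inhibition and lower numbers for stronger inhibition), the series begins with compound 1 `O=C(Nc1cccc(C(F)(F)F)c1)N[C@H]1CC[C@H](O)CC1`. Compound 1 reaches only the limit of the assay at > 20000 nM, a limit and not a number (the limit of > 20000 nM in this assay, at which 1 of the 3 values shown sits). Compound 2 `O=C(Nc1cccc(C(F)(F)F)c1)N[C@H]1CC[C@H](Oc2cccc(C(F)(F)F)c2)CC1` gives 1300 nM in this assay, and compound 3 `O=C(Nc1cccc(C(F)(F)F)c1)N[C@H]1CC[C@H](Oc2ccc(C(F)(F)F)cc2)CC1` gives 460 nM. Among the two numbers shown compound 3 stands lowest, with compound 2 nearest: the step was a 2.8-fold lower number from compound 2 to compound 3 (0.45 log units; beyond the scatter). Building the aryl ether onto the alcohol of compound 1 gave an at least 15-fold lower number from compound 1 to compound 2 (1.18 log units; beyond the scatter) and an at least 43-fold lower number from compound 1 to compound 3 (1.63 log units; beyond the scatter).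

Compound 4 `O=C(Nc1cccc(C(F)(F)F)c1)N[C@H]1CC[C@H](Oc2ccc(OC(F)(F)F)cc2)CC1` differs from compound 3 only in this: trifluoromethoxy in place of trifluoromethyl on an aromatic carbon. Going by the values given here, no measured step swaps these two groups; the measured steps concern the presence of the aryl ether and the placement of trifluoromethyl on it, and only the latter, modest one bears on a change at the same aromatic carbon. A step no larger than the scatter is therefore expected, in either direction. Compound 4 is expected to give about 500 nM, between 200 nM and 1300 nM. The expected step is a 1.1-fold higher number from compound 3 to compound 4 (0.04 log units; within the scatter).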

Compound 4, half-maximal inhibitory concentration: 690 nM
Compound 4: the middle estimate sits 1.4-fold (0.14 log units) below what was measured, within the range that was stated.
By their numbers in this assay, from the lowest: compounds 3, 4 and 2 (each within the scatter of the next, the first and the last beyond it). At a limit, above all of these: compound 1.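

In this assay, the aromatic carbon that carries trifluoromethyl in compound 3 also takes trifluoromethoxy, with a 1.5-fold higher number from compound 3 to compound 4 (0.18 log units; within the scatter). The earlier compounds shown here showed only that moving trifluoromethyl on the aryl ether changes the number; this swap shows that at the same carbon, para to a large group, the change to trifluoromethoxy, with its added oxygen and one hydrogen-bond acceptor, cannot be told apart from no change at all in this read-out. Nothing shown here gives a cause for this result.

From the compounds shown here alone, it stays open whether that carbon would accept groups of another kind, such as an amine, a carboxylic acid or a longer alkyl chain. Also open, going by these compounds, is how trifluoromethoxy would fare at the place trifluoromethyl holds in compound 2, or on the other aromatic ring of the shared core.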